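This account rests on a few compounds, and the source may have more. Where it says the series, first, only, none or still open, it means among the compounds named here.

Working notes on the series in a functional assay on BCG823 cells (Homo sapiens) for inhibition, read by MTT assay, with a stated time of 72 h; on this read-out lower numbers stand for stronger inhibition and higher numbers for weaker inhibition. Of the compounds shown here, three have numbers so far. Compound 1 `CN(C(=O)NC(=O)c1ccccc1F)c1nc(C(F)(F)F)c(C(=O)N/N=C/c2ccc(C(F)(F)F)cc2)s1` gives 3.87 ug/mL. Compound 2 `CN(C(=O)NC(=O)c1c(F)cccc1F)c1nc(C(F)(F)F)c(C(=O)N/N=C/c2cc(C(F)(F)F)cc(C(F)(F)F)c2)s1` gives 5.28 ug/mL. Compound 3 `Cc1nc(N(C)C(=O)NC(=O)c2c(F)cccc2F)sc1C(=O)N/N=C/c1cc(C(F)(F)F)cc(C(F)(F)F)c1` gives 14.1 ug/mL. On these three numbers compound 2 stands second highest; compound 1 is its nearest neighbour and lies within the scatter of it, while compound 3 is the furthest from it and lies beyond the scatter.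

One single-point step is available: a 2.7-fold higher number from compound 2 to compound 3 (0.43 log units; beyond the scatter). This step changes the shared core and does not touch the ring on the carbonyl carbon, so it does not bear on the change considered here. Among the measured compounds shown here, compound 1 and compound 2 differ in two places at once, and their two values show only that those two changes together stay within the scatter.

Compound 4 `CN(C(=O)NC(=O)c1ccc(Cl)cc1Cl)c1nc(C(F)(F)F)c(C(=O)N/N=C/c2cc(C(F)(F)F)cc(C(F)(F)F)c2)s1` is the next compound. Relative to compound 2 the change is 2,4-dichlorophenyl in place of 2,6-difluorophenyl on a carbonyl carbon. For the measured compounds named here, no measured step alters this ring, so there is nothing in the data to fix a direction. The expectation is therefore a step of no size beyond the scatter, a 1.1-fold lower number from compound 2 to compound 4 (0.02 log units; within the scatter), with the range kept wide for lack of a bearing step. For compound 4 the estimated value is 5 ug/mL, within a range of 2 ug/mL to 13 ug/mL.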

Compound 4, half-maximal inhibitory concentration: > 100 ug/mL
Compound 4 was reported as a limit; the forecaster's own chance of this, stated with the estimate: 5%; at least 20-fold (1.30 log units) between middle value and limit.
By their numbers in this assay, from the lowest: compounds 1 and 2 (each within the scatter of the next); then compound 3. At a limit, above all of these: compound 4.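

Compound 4 in this assay is reported only as a limit of the assay, not as a number: the limit of > 100 ug/mL in this assay, at which 1 of the 4 values shown sits.

Among the compounds shown here, no earlier step touched the ring on the carbonyl carbon, and this first reading shows that the position is not indifferent to change, with an at least 18-fold higher number from compound 2 to compound 4 (1.27 log units; beyond the scatter) for 2,4-dichlorophenyl in place of 2,6-difluorophenyl. For the compounds shown here, that step is also larger than a 2.7-fold higher number from compound 2 to compound 3 (0.43 log units; beyond the scatter), the only other single-place step, and the two rings match in every count computed for them: heavy atoms, hydrogen-bond donors, hydrogen-bond acceptors and net charge, so these counts do not separate them.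

The change replaces both the halogen and its placement on the ring, and the compounds shown do not tell these two parts apart, while the limit leaves the full size of the step unknown. Going by these compounds, it also remains open how this position would respond to a ring carrying a methoxy group or an amine in place of the halogens, or to an unsubstituted phenyl ring.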